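A few compounds are considered here, and "the series" means these few. Any claim that something is new, unique, unknown or untested is made for them only; others in the source may bear on it.

Measured compounds:
compound 1 `CCOc1ccc(NC(=O)c2c(N)n[nH]c2NC)cc1` — 31000 nM
compound 2 `CCOc1ccc(NC(=O)c2c(N)n[nH]c2Nc2ccccc2)cc1` — 21000 nM
compound 3 `CCOc1ccc(NC(=O)/C(C#N)=C(\Nc2ccccc2)SC)cc1` — 49300 nM

In a functional assay on PANC-1 cells (Homo sapiens) for cytotoxicity, read by resazurin assay, with a stated time of 48 h (on this read-out higher numbers stand for weaker inhibition and lower numbers for stronger inhibition), compound 3 gives a number above both others, and the gap to compound 2 lies beyond the scatter. Compound 4 `CCOc1ccc(NC(=O)/C(C#N)=C(\NC)SC)cc1` is not yet measured. It arises from compound 3 by the change (methyl in place of phenyl on an amine nitrogen). The same kind of change connects compound 2 to compound 1, (methyl in place of phenyl on a nitrogen on an aromatic ring), and there it gave a 1.5-fold higher number from compound 2 to compound 1 (0.17 log units; within the scatter). The two places differ: in the first pair the nitrogen sits on an aromatic ring with an aromatic carbon neighbour, in the second it is an amine nitrogen joined to a double-bonded chain carbon. The difference between the two cores is not broken down here. For compound 4, the step of a 1.3-fold higher number from compound 3 to compound 4 (0.12 log units; within the scatter) is expected to be about as small as the earlier one, because a 1.5-fold higher number from compound 2 to compound 1 (0.17 log units; within the scatter) stayed within the scatter. Compound 4 is therefore estimated at 65000 nM, likely between 30000 nM and 140000 nM.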

Compound 4, half-maximal inhibitory concentration: 26400 nM
Beside the measured number, compound 4's estimate is 2.5-fold (0.39 log units) above it; measured number outside the range, below it.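

In this assay, putting methyl in place of phenyl on the amine nitrogen gives a 1.9-fold lower number from compound 3 to compound 4 (0.27 log units; within the scatter), a step that on its own is no larger than repeat measurements can produce. Set against the same change on the other core, this step shows that the outcome does not carry over unchanged from one core to the other: the same change on two cores in this assay, a 1.5-fold higher number (0.17 log units; within the scatter) from compound 2 to compound 1 and a 1.9-fold lower number (0.27 log units; within the scatter) from compound 3 to compound 4, 2.8-fold (0.44 log units) apart, beyond the scatter of two such steps. Within the data shown here, with only two pairs, this gives no general rule for other cores and does not show what about the cores sets them apart.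

The compounds shown leave open how a group other than phenyl or methyl on this nitrogen, such as a propyl chain or a benzyl group, would behave on either core.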